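Tetrazolyl in place of methylsulfonyl on a shared thiazole core

The source may report more compounds than this note shows. Statements on the series, on what has been measured and on what is new or still open speak of the compounds shown alone.

Of the compounds shown here, two have so far been measured in a functional assay on isolated protein for agonist activity at Glucose-dependent insulinotropic receptor (Homo sapiens), read by HTRF and cAMP accumulation; on this read-out lower numbers stand for an effect already at smaller amounts and higher numbers for an effect only at larger amounts of compound. Compound 2 `CCc1cnc(N2CC=C(c3nc(COc4ccc(S(C)(=O)=O)cc4)cs3)CC2)nc1` gives 70.5 nM in this assay. Compound 1 `CC(C)(C)OC(=O)N1CC=C(c2nc(COc3ccc(-n4cnnn4)cc3)cs2)CC1`, which carries a different head group and a different ring substituent, gives 113 nM in this assay; the gap between the two lies within the usual scatter of repeated measurements, so the numbers cannot be told apart with confidence.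

Compound 3 `CCc1cnc(N2CC=C(c3nc(COc4ccc(-n5cnnn5)cc4)cs3)CC2)nc1` has not yet been measured. It keeps the ethylpyrimidine head of compound 2 and alters only the group on the phenyl ether: 1H-tetrazol-1-yl in place of methylsulfonyl on an aromatic carbon. Among the measured compounds shown here, the same tetrazolyl group is present in compound 1, whose value sits close to that of compound 2, but the two measured compounds differ in a second place as well, so no single step isolates this exchange.

For the measured compounds named here, with no clean precedent, the step from compound 2 to compound 3 is expected to be small, a 1.2-fold higher number from compound 2 to compound 3 (0.08 log units; within the scatter), in either direction or none beyond the scatter. Compound 3 is therefore estimated at 85 nM in this assay, with a range from 35 nM to 210 nM.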

Compound 3, half-maximal effective concentration: 4.9 nM
The estimate for compound 3 lay 17-fold (1.24 log units) above the measured number, outside the stated range (below it).
By their numbers in this assay, from the lowest: compound 3; then compounds 2 and 1 (each within the scatter of the next).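

In this assay, with the 5-ethylpyrimidin-2-yl head held fixed, 1H-tetrazol-1-yl in place of methylsulfonyl on the aromatic carbon gives a 14-fold lower number from compound 2 to compound 3 (1.16 log units; beyond the scatter) and so isolates this exchange, which the two earlier compounds could not do because they differ in two places. The head group counts as well: with 1H-tetrazol-1-yl held fixed, 5-ethylpyrimidin-2-yl in place of tert-butoxycarbonyl on the amine nitrogen in the ring gives a 23-fold lower number from compound 1 to compound 3 (1.36 log units; beyond the scatter) as a second large step. The values of compound 1 and compound 2 could not be told apart, yet each lies a large step from compound 3, so their closeness said nothing about either change taken alone.

No independent data are available that bear on why either exchange has so large an effect on this result. The compounds shown leave open how a carboxylic acid, a primary amide or a nitrile would compare with 1H-tetrazol-1-yl on the same aromatic carbon, and whether a longer chain in place of the ethyl group on the pyrimidine head would keep the low number of compound 3.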